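Two Measured Amides and a Third Awaiting a Number

The source may report more compounds than this note shows. Statements on the series, on what has been measured and on what is new or still open speak of the compounds shown alone.

Measured so far:
compound 1 `CC(C)(C)c1nc2c(C(=O)NCC3CCN(CC(O)CN4CCN(S(C)(=O)=O)CC4)CC3)cccc2[nH]1` gives 12.6 nM;
compound 2 `COC(=O)N1CCN(CCN2CCC(CNC(=O)c3cccc4[nH]c(C(C)C)nc34)CC2)CC1` gives 1.59 nM.

Both compounds share a core with an amide hydrogen and differ in the basic side chain beyond it. In an assay on isolated protein for binding affinity to 5-hydroxytryptamine receptor 4 (Homo sapiens) (on this read-out higher numbers stand for weaker inhibition and lower numbers for stronger inhibition), compound 2 gives 1.59 nM, the lower of the two numbers; compound 1 gives 12.6 nM, and the gap between them is stated to lie beyond the scatter. Going by the values given here, no step between two measured compounds differing in a single place is available, so the pair only shows that the side chain matters.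

Compound 3 `CC(=O)N1CCC(CN2CCC(CNC(=O)c3cccc4[nH]c(C(C)C)nc34)CC2)CC1` is the next compound in line. It differs from compound 2 in one place: 1-acetylpiperidin-4-yl in place of (4-(methoxycarbonyl)piperazin-1-yl)methyl on a saturated chain carbon bound to an amine nitrogen in a ring. Among the compounds with values here, with no comparable step measured, the expected step from compound 2 to compound 3 in this assay is a modest loss, a 2.0-fold higher number from compound 2 to compound 3 (0.30 log units; within the scatter), though a step within the scatter would not surprise. Compound 3 is estimated at 3.2 nM, with a range from 1 nM to 10 nM.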

Compound 3, inhibition constant: 1 nM
For compound 3 the middle estimate is 3.2-fold (0.51 log units) above the measured one; the measured number falls inside the stated range.
By their numbers in this assay, from the lowest: compounds 3 and 2 (each within the scatter of the next); then compound 1.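

At the place printed as a saturated chain carbon bound to an amine nitrogen in a ring, the exchange gives the series its first step that can be read at a single place: in this assay, 1-acetylpiperidin-4-yl in place of (4-(methoxycarbonyl)piperazin-1-yl)methyl gives a 1.6-fold lower number from compound 2 to compound 3 (0.20 log units; within the scatter). The entering group has 9 heavy atoms and 1 hydrogen-bond acceptor, fewer of each than the group it replaces, and it has one hetero atom in its six-membered ring rather than 2, so for this pair these differences come without a step beyond the scatter. No measurement at hand bears on why the two groups read alike.

From the compounds shown here alone, whether a piperidine with a free amine in place of the acetyl group, or a longer chain carrying the same ring, would also stay within the scatter of compound 3 remains open. Going by these compounds, this is a single step on a single core, so whether the same exchange would read alike on the core of compound 1 is also open, and no pattern for this place can be drawn from it.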